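Series notes: piperidine nitrogen substituent change, compound 3 to 4

The compounds below may be only part of what the source reports. "The series", "measured", "known", "first", "only" and "open" are said of these compounds alone.

Measured so far:
- compound 1, `CC(C)(C)OC(=O)N1CCC(O[C@H]2CC[C@H](Oc3ccc(S(C)(=O)=O)c(F)c3)CC2)CC1`: 52 nM
- compound 2, `CC(C)(C)OC(=O)N1CCC(O[C@H]2CC[C@H](Oc3ccc(S(C)(=O)=O)nn3)CC2)CC1`: 651 nM
- compound 3, `CC1(OC(=O)N2CCC(O[C@H]3CC[C@H](Oc4cnc(S(C)(=O)=O)cn4)CC3)CC2)CC1`: 25.9 nM

All three values come from a functional assay on isolated protein for agonist activity at Glucose-dependent insulinotropic receptor (Homo sapiens), read by HTRF and cAMP accumulation; a lower number here means that less compound is needed, a higher number that more compound is needed for the effect. Compound 3 carries the lowest number of the three. Its gap to compound 1 lies within the scatter, so the two cannot be ordered against each other; its gap to compound 2 lies beyond the scatter, and compound 2 is the weakest of the set. The shared core of compounds 1 to 3 is kept in compound 4, `CC(C)c1noc(CN2CCC(O[C@H]3CC[C@H](Oc4cnc(S(C)(=O)=O)cn4)CC3)CC2)n1`, which is not yet measured in this assay. Relative to compound 3 the change is (3-isopropyl-1,2,4-oxadiazol-5-yl)methyl in place of ((1-methylcyclopropyl)oxy)carbonyl on an amine nitrogen in a ring.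

Among the measured compounds shown here, no measured pair in the set shows what this change does, and the data give no step to lean on. Because compound 3 gives 25.9 nM in this assay, and the core is left untouched, the expectation is for a step of modest size, most likely none beyond the scatter, with the direction open. The estimated step is a 1.3-fold lower number from compound 3 to compound 4 (0.11 log units; within the scatter). For compound 4 the estimated value in this assay is 20 nM, with a range from 5 nM to 80 nM.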

Compound 4, half-maximal effective concentration: 14 nM
Estimate against measurement, compound 4: 1.4-fold (0.15 log units) above; measured number inside the range.
By their numbers in this assay, from the lowest: compounds 4, 3 and 1 (each within the scatter of the next, the first and the last beyond it); then compound 2.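

In this assay the (3-isopropyl-1,2,4-oxadiazol-5-yl)methyl in place of ((1-methylcyclopropyl)oxy)carbonyl gives a 1.9-fold lower number from compound 3 to compound 4 (0.27 log units; within the scatter) and thus leaves the number unchanged within the scatter. Compounds 1 to 3 all carry a carbonyl on the amine nitrogen in the ring, whereas compound 4 shows that this carbonyl is not needed for agonist activity at this level, and that a five-membered aromatic ring with 3 hetero atoms is accepted at this position. Nothing measured on either group accounts for the result.

On these data alone, whether the same exchange holds on the cores of compound 1 and compound 2 remains open. So does the role of the methylene link and the isopropyl, which a pyrimidine ring bonded directly to the nitrogen or a tert-butyl on the oxadiazole would test.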